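The compounds below may be only part of what the source reports. "The series", "measured", "known", "first", "only" and "open" are said of these compounds alone.

In a functional assay on SK-MEL-5 cells (Homo sapiens) for inhibition, read by sulforhodamine B assay, with a stated time of 48 h (a lower number here means a stronger inhibitor of growth, a higher number a weaker inhibitor of growth), three compounds have been measured. Compound 1 `COc1cc(-c2nn(-c3cccc(NC(=O)c4cccc(C(F)(F)F)c4)c3)cc2-c2ccncc2)ccc1Cl` gives 2470 nM, compound 2 `COc1cc(-c2nn(-c3cccc(NC(=O)Nc4ccc(Cl)c(Cl)c4)c3)cc2-c2ccncc2)ccc1Cl` gives 1490 nM and compound 3 `O=C(Nc1cccc(-n2cc(-c3ccncc3)c(-c3ccc(Cl)c(O)c3)n2)c1)Nc1ccc(Cl)c(Cl)c1` gives 1160 nM. Compound 2 holds the second highest of these three numbers, but it lies within the scatter of both others.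

Compound 4 `COc1cc(-c2nn(-c3cccc(NC(=O)c4ccc(Cl)c(C(F)(F)F)c4)c3)cc2-c2ccncc2)ccc1Cl` has not yet been measured. It differs from compound 2 by 4-chloro-3-(trifluoromethyl)phenyl in place of (3,4-dichlorophenyl)amino on a carbonyl carbon.

Among the measured compounds shown here, the closest precedent is a 1.7-fold lower number from compound 1 to compound 2 (0.22 log units; within the scatter), a change on the same carbonyl carbon that stayed within the scatter. The other measured step, a 1.3-fold lower number from compound 2 to compound 3 (0.11 log units; within the scatter), also within the scatter, concerns a methyl on an oxygen, which compound 4 keeps, so it bears on this change only weakly. No shift beyond the scatter is therefore expected in this assay, and the estimated change is small and towards a higher number: a 1.2-fold higher number from compound 2 to compound 4 (0.08 log units; within the scatter). Compound 4 is expected at 1800 nM, with an estimated range of 900 nM to 3600 nM.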

Compound 4, concentration for total growth inhibition: 6870 nM
For compound 4 the middle estimate is 3.8-fold (0.58 log units) below the measured one; the whole stated range lies below it.
By their numbers in this assay, from the lowest: compounds 3, 2 and 1 (each within the scatter of the next, the first and the last beyond it); then compound 4.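

In this assay, the carbonyl carbon had so far shown only a change within the scatter, but a 4.6-fold higher number from compound 2 to compound 4 (0.66 log units; beyond the scatter) is a step beyond it, with 4-chloro-3-(trifluoromethyl)phenyl in place of (3,4-dichlorophenyl)amino. Chloro in place of hydrogen on an aromatic carbon is also enough by itself to give a step beyond the scatter, a 2.8-fold higher number from compound 1 to compound 4 (0.44 log units; beyond the scatter). Compound 1 also lacks the (3,4-dichlorophenyl)amino group yet lies within the scatter of compound 2, and the gap beyond the scatter appears only with the added chloro.

No data shown bear on the reason for these steps.

Going by these compounds, it remains open whether a fluoro, a methyl or an amine on that aromatic carbon would give a similar step. The compounds shown also leave open whether chloro would have the same effect in a compound carrying the hydroxy group of compound 3.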